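Series notes: the step from compound 2 to compound 4

The source may hold more compounds than are shown below. What is called first, only, known or untested is meant among the compounds shown, and "the series" means these compounds.

Within the data shown here, compound 2 `Cc1cccc(C(=O)NC(CCN(C)C)c2ccc(Cl)cc2)c1C` gives 3630 nM in an assay on NIH3T3 cells with Urotensin-2 receptor (Homo sapiens) as the target (on this read-out lower numbers stand for an effect already at smaller amounts and higher numbers for an effect only at larger amounts of compound), the second highest of the three numbers measured so far. Compound 1 `COc1ccc(C(=O)NC(CCN(C)C)c2ccc(Cl)cc2)cc1` gives 1350 nM, and the step of a 2.7-fold higher number from compound 1 to compound 2 (0.43 log units; beyond the scatter) is a modest one, beyond the scatter. Compound 3 `COc1cccc(C(=O)NC(CCN(C)C)c2ccc(Cl)cc2)c1C` gives 4270 nM; the step of a 1.2-fold higher number from compound 2 to compound 3 (0.07 log units; within the scatter) stays within the scatter, so compounds 2 and 3 cannot be told apart on this read-out.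

Compound 4 `Cc1ccc(C)c(C(=O)NC(CCN(C)C)c2ccc(Cl)cc2)c1` differs from compound 2 in one place: 2,5-dimethylphenyl in place of 2,3-dimethylphenyl on a carbonyl carbon. Among the measured compounds shown here, no measured step swaps two dimethyl patterns on that ring; the step from compound 1 to compound 2 changes the whole substitution pattern together with its group, and the step from compound 2 to compound 3 changes the group itself. Neither bears directly on a methyl moved to another position, so the expectation is a step of a 1.1-fold lower number from compound 2 to compound 4 (0.05 log units; within the scatter) that is expected to stay within the scatter. On that basis compound 4 is estimated to give 3200 nM in this assay, with a range from 1200 nM to 8500 nM.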

Compound 4, half-maximal effective concentration: 2880 nM
Beside the measured number, compound 4's estimate is 1.1-fold (0.05 log units) above it; the measured number falls inside the stated range.
By their numbers in this assay, from the lowest: compound 1; then compounds 4, 2 and 3 (each within the scatter of the next).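

In this assay, among these compounds, 2,5-dimethylphenyl in place of 2,3-dimethylphenyl on a carbonyl carbon gives a 1.3-fold lower number from compound 2 to compound 4 (0.10 log units; within the scatter) so these two dimethyl patterns cannot be told apart on this read-out, a swap that no earlier step covered. With 4-methoxyphenyl as the reference at the same place, the change gives a 2.1-fold higher number from compound 1 to compound 4 (0.33 log units; beyond the scatter) so the modest gap seen with the 2,3-dimethylphenyl group in compound 2 also appears with a second dimethyl pattern. No supporting data on the origin of these numbers accompany the series.

Open, from the compounds shown here alone, is whether an unsubstituted phenyl, a single methyl, or an aminophenyl or carboxyphenyl group on the carbonyl carbon would move the number beyond the scatter. Also open, going by these compounds, is how a longer chain in place of the dimethylaminoethyl arm would read with either dimethylphenyl group.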